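A Larger Change on the Shared Core of Compound 1

A few compounds are considered here, and "the series" means these few. Any claim that something is new, unique, unknown or untested is made for them only; others in the source may bear on it.

Of the compounds shown here, three built on a shared core have been measured in an assay on isolated protein for inhibition of Gonadotropin-releasing hormone receptor (Homo sapiens); a higher number here means a weaker inhibitor, a lower number a stronger inhibitor. Compound 1 `CCCn1c(SCc2cc([N+](=O)[O-])ccc2OC)nc2cc(NC(=O)NC(C)(C)C)ccc21` gives 18 nM. Compound 2 `CCCCn1c(SCc2cc([N+](=O)[O-])ccc2OC)nc2cc(NC(=O)NC(C)(C)C)ccc21` gives 23 nM, and compound 3 `COc1ccc([N+](=O)[O-])cc1CSc1nc2cc(NC(=O)NC(C)(C)C)ccc2n1C(C)C` gives 62 nM. Compound 1 thus holds the lowest of the three numbers: the step of a 1.3-fold higher number from compound 1 to compound 2 (0.11 log units; within the scatter) stays within the scatter, whereas a 3.4-fold higher number from compound 1 to compound 3 (0.54 log units; beyond the scatter) and a 2.7-fold higher number from compound 2 to compound 3 (0.43 log units; beyond the scatter) go beyond it, both modest.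

Compound 4 `CCCn1c(SCc2cc([N+](=O)[O-])ccc2OC)nc2cc(NC(=O)NC(C)(C)C)cc(C(=O)NCCCN(C)C)c21` keeps the propyl on the aromatic nitrogen of compound 1 and differs from it in one place: (3-(dimethylamino)propyl)carbamoyl in place of hydrogen on an aromatic carbon. All three measured steps exchange one group for another on the aromatic nitrogen; none of them touches a hydrogen on the six-membered aromatic ring of carbon only, so none bears directly on this change. What they show is only that variation elsewhere on the core shifted the number in this assay by a modest amount or less. The change to compound 4 introduces far more than any of them, so a wider range is appropriate, with no direction favoured. For compound 4 an estimate of 30 nM is taken, with a range from 6 nM to 150 nM. This corresponds to an expected step of a 1.7-fold higher number from compound 1 to compound 4 (0.22 log units; within the scatter).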

Compound 4, half-maximal inhibitory concentration: 170 nM
Estimate against measurement, compound 4: 5.7-fold (0.75 log units) below, and the stated range ends below it.
By their numbers in this assay, from the lowest: compounds 1 and 2 (each within the scatter of the next); then compound 3; then compound 4.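

In this assay, within the data shown here, the step of a 9.4-fold higher number from compound 1 to compound 4 (0.98 log units; beyond the scatter) gives the first reading for this position, an aromatic carbon of a six-membered aromatic ring of carbon only, ortho to a fused ring and meta to the ((tert-butyl)carbamoyl)amino group. The step is larger than any of the exchanges on the aromatic nitrogen, of which the largest is a 3.4-fold higher number from compound 1 to compound 3 (0.54 log units; beyond the scatter), so in this one pair (3-(dimethylamino)propyl)carbamoyl in place of hydrogen goes with a weaker number, although compound 4 still gives a nanomolar value of 170 nM. Nothing in the data shown indicates which part of the entering group goes with this rise.

The compounds shown leave open whether the rise belongs to the whole group or to one part of it, which a primary carboxamide, a carboxylic acid or a propyl amide ending in a hydroxyl group at the same carbon could help to separate. With a single pair at this position, they also leave open whether a shorter chain or a longer chain on the amide would move the number, and in which direction.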